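Trifluoromethyl for cyano in an enamide series

A few compounds are considered here, and "the series" means these few. Any claim that something is new, unique, unknown or untested is made for them only; others in the source may bear on it.

Going by the values given here, compound 1 `CC(Cl)/C=C/C(=O)N(Cc1ccc(C#N)cc1)CC(C)C` gives 63100 nM in an assay on isolated protein (Gossypium hirsutum) for inhibition of protoporphyrinogen oxidase 1, chloroplastic (Arabidopsis thaliana) (on this read-out higher numbers stand for weaker inhibition and lower numbers for stronger inhibition), the highest of the two numbers known; compound 2 `CC(Br)/C=C/C(=O)N(Cc1ccc(Cl)cc1)CC(C)C` gives 10000 nM in this assay. Compound 3 `CC(Cl)/C=C/C(=O)N(Cc1ccc(C(F)(F)F)cc1)CC(C)C` differs from compound 1 by trifluoromethyl in place of cyano on an aromatic carbon. Among the compounds with values here, no step of this kind has been measured, so the size is uncertain; a moderate drop, somewhat beyond the scatter, is expected, since compound 2 with its chloro group shows 10000 nM. The estimated step of a 3.2-fold lower number from compound 1 to compound 3 (0.50 log units; beyond the scatter) leads to an expected value for compound 3 of 20000 nM, within a range of 5000 nM to 80000 nM.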

Compound 3, half-maximal inhibitory concentration: 5010 nM
The estimate for compound 3 lay 4.0-fold (0.60 log units) above the measured number; low and high end bracket the measured number.
By their numbers in this assay, from the lowest: compounds 3 and 2 (each within the scatter of the next); then compound 1.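

Trifluoromethyl in place of cyano on the aromatic carbon gives, in this assay, a 13-fold lower number from compound 1 to compound 3 (1.10 log units; beyond the scatter), the only step in this series that can be read between compounds differing in one place. It shows that this position, para to a large group, is sensitive to the substituent it carries while the core of compound 1 stays unchanged. Nothing shown here accounts for the size of this step. As far as these compounds go, it remains open how an amine, a carboxylic acid or a methoxy group would fare on this aromatic carbon. From the compounds shown here alone, whether the step holds with bromine in place of the chlorine on the chain also remains open.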